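Amine exchange on the shared core: compound 1 to compound 3

The compounds below may be only part of what the source reports. "The series", "measured", "known", "first", "only" and "open" are said of these compounds alone.

Two compounds of the series carry numbers in an assay on isolated protein for binding affinity to corticotropin-releasing factor receptor 1 (Homo sapiens); on this read-out higher numbers stand for weaker inhibition and lower numbers for stronger inhibition. Compound 1 `CCN(c1nc(C)nc(N(CC2CC2)CC2CC2)n1)c1ccc(N(C)C)cc1C(F)(F)F` gives 5 nM in this assay. Compound 2 `CCN(c1nc(C)cc(C)n1)c1ccc(OC)cc1Br` gives 35 nM in this assay. Compound 1 thus holds the lower of the two numbers; the number of compound 2 is higher, and the gap between them lies beyond the usual scatter. Going by the values given here, no pair of measured compounds differs in a single place, so no measured step sets a scale for what follows.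

Compound 3 `CCCCN(CC#N)c1nc(C)nc(N(CC)c2ccc(N(C)C)cc2C(F)(F)F)n1` differs from compound 1 in one place: butyl(cyanomethyl)amino in place of bis(cyclopropylmethyl)amino on an aromatic carbon. Two three-membered non-aromatic rings of carbon only go out and a butyl chain with a nitrile comes in, on the aromatic carbon between two ring nitrogen atoms. Among the compounds with values here, nothing among the measured compounds shows what such an exchange does in this assay. The expected step from compound 1 to compound 3 is a 1.6-fold higher number from compound 1 to compound 3 (0.20 log units; within the scatter), small, within or close to the scatter, if anything towards a higher number. Compound 3 is therefore estimated at 8 nM in this assay, with a range from 2.5 nM to 30 nM.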

Compound 3, inhibition constant: 6 nM
Compound 3: middle estimate off by 1.3-fold (0.12 log units), on the high side; the range from low to high includes it.
By their numbers in this assay, from the lowest: compounds 1 and 3 (each within the scatter of the next); then compound 2.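

In this assay, going by these compounds alone, the exchange of bis(cyclopropylmethyl)amino for butyl(cyanomethyl)amino on the aromatic carbon between two ring nitrogen atoms gives a 1.2-fold higher number from compound 1 to compound 3 (0.08 log units; within the scatter), the first single-place step, and compound 1 and compound 3 cannot be told apart. For this pair, then, the two three-membered rings of carbon only are not needed to keep the number at this level, and an open butyl chain with a nitrile on the same amine nitrogen reads alike in this assay. Nothing measured here bears on why the two amines read alike.

The step swaps both substituents of the amine at once, so the compounds shown leave open what the butyl chain and the nitrile each contribute; dibutylamino or butyl(cyclopropylmethyl)amino at this position would separate them. From the compounds shown here alone, how far the position reaches beyond these two large amines also stays open, for instance with a small dimethylamino group, a cyclic morpholine, or a carboxylic acid in place of the nitrile.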